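The source may hold more compounds than are shown below. What is called first, only, known or untested is meant among the compounds shown, and "the series" means these compounds.

Measured in a functional assay on MGC-803 cells (Homo sapiens) for antiproliferative activity, read by MTT assay, with a stated time of 72 h; a higher number here means a weaker inhibitor, a lower number a stronger inhibitor:
- compound 1 `CCCSc1nc(Cl)c2c(n1)N(Cc1ccccc1)C(C(=O)N1CCN(Cc3ccccc3)CC1)N2`: 51200 nM
- compound 2 `CCCSc1nc(Cl)c2c(n1)N(Cc1ccccc1)C(C(=O)O)N2`: > 64000 nM (a limit)
- compound 3 `CCCSc1nc(Cl)c2c(n1)N(CC1CCCCC1)C(C(=O)N1CCN(C)CC1)N2`: > 64000 nM (a limit)

Compound 2 stands at the limit of > 64000 nM in this assay, at which 2 of the 3 values shown sit; no number is known for it, only that limit. Compound 3 likewise reports only a limit. Going by the values given here, compound 1 is the one amide with a number in this assay, and it is a weak one.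

Compound 4 `CCCSc1nc(Cl)c2c(n1)N(Cc1ccccc1)C(C(=O)NCC(C)C)N2` differs from compound 2 by isobutylamino in place of hydroxy on a carbonyl carbon. Among the compounds with values here, no step between measured compounds is known, so the direction of this change is open; the amides seen so far give no ground to expect a gain. The step from compound 2 to compound 4 is expected to be an at least 1.0-fold lower number from compound 2 to compound 4 (0.02 log units; that floor lies within the scatter), nothing beyond the scatter. Compound 4 is therefore estimated at 60000 nM, within 20000 nM to 150000 nM, and quite possibly again only a limit.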

Compound 4, half-maximal inhibitory concentration: 58400 nM
Compound 4: middle estimate off by 1.0-fold (0.01 log units), on the high side, and the stated range covers the measured number.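

Compound 2 holds only a limit in this assay: the limit of > 64000 nM in this assay, at which 2 of the 4 values shown sit.

Isobutylamino in place of hydroxy on a carbonyl carbon gives an at least 1.0-fold lower number from compound 2 to compound 4 (0.03 log units; that floor lies within the scatter), so this change shows no gain beyond the scatter. Compound 4 does give a number, 58400 nM, which puts a measured value on an open-chain amide at this position, though activity remains weak.

From the compounds shown here alone, the true value of compound 2 stays unknown. Going by these compounds, whether a methyl ester, a primary amide or a longer alkyl chain on the amide nitrogen would shift the number beyond the scatter also stays open.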